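A few compounds are considered here, and "the series" means these few. Any claim that something is new, unique, unknown or untested is made for them only; others in the source may bear on it.

Going by the values given here, compound 1 `O=C(Nc1ccc(Oc2ccnc3[nH]ccc23)cc1)c1cc2cccnc2n(-c2ccc(Cl)cc2)c1=O` gives 280 nM in a functional assay on HT-29 cells (Homo sapiens) for antiproliferative activity, read by MTT assay, with a stated time of 72 h (on this read-out higher numbers stand for weaker inhibition and lower numbers for stronger inhibition), the lowest of the two numbers so far. Compound 2 `O=C(Nc1ccc(Oc2ccnc3[nH]ccc23)cc1)c1cc2cccnc2n(-c2ccc(C(F)(F)F)cc2Cl)c1=O` gives 2160 nM, and the step of a 7.7-fold higher number from compound 1 to compound 2 (0.89 log units; beyond the scatter) comes from replacing the group on the aromatic nitrogen. Compound 3 `O=C(Nc1ccc(Oc2ccnc3[nH]ccc23)c(F)c1)c1cc2cccnc2n(-c2ccc(Cl)cc2)c1=O` keeps that group and instead carries the change (fluoro in place of hydrogen on an aromatic carbon), set ortho to a large group and meta to a large group. Among the compounds with values here, no measured step touches this part of the molecule, so nothing here argues for a move beyond the scatter. Compound 3 is therefore expected near compound 1, at 250 nM with a range from 100 nM to 700 nM, which means an expected step of a 1.1-fold lower number from compound 1 to compound 3 (0.05 log units; within the scatter).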

Compound 3, half-maximal inhibitory concentration: 82 nM
Compound 3: middle estimate off by 3.0-fold (0.48 log units), on the high side; the measured number lies below the stated range.
By their numbers in this assay, from the lowest: compound 3; then compound 1; then compound 2.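

Placing fluoro in place of hydrogen on an aromatic carbon, ortho to a large group and meta to a large group, gives a step beyond the scatter in this assay, namely a 3.4-fold lower number from compound 1 to compound 3 (0.53 log units; beyond the scatter). This part of the molecule, untouched by the earlier step, therefore responds to the addition of a single heavy atom, with stronger inhibition. Nothing given here explains why.

As far as these compounds go, whether a chloro or methoxy group on this carbon would give a similar step stays open. So does whether fluoro would act the same way alongside the nitrogen substituent of compound 2.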